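This account rests on a few compounds, and the source may have more. Where it says the series, first, only, none or still open, it means among the compounds named here.

Measured so far: compound 1 `CCOC(=O)C1=C(C)N/C(=N\C#N)NC1c1ccsc1` with 23%; compound 2 `CCOC(=O)C1=C(C)N/C(=N\C#N)NC1c1ccccc1` with 13%.

Among the measured compounds shown here, in an assay on HeLa cells for displacement of a labelled ligand from adenosine receptor A3 (Homo sapiens), with a stated time of 180 min, tested at 1 uM (a higher number here means more inhibition at the concentration tested (going by the name of the read-out), a lower number less inhibition), compound 2 stands within the scatter of compound 1, the only other measured compound, the step being a number 10 percentage points lower from compound 1 to compound 2 (within the scatter). Compound 3 `CCOC(=O)C1=C(C)N/C(=N\C#N)NC1c1ccoc1` differs from compound 2 by furan-3-yl in place of phenyl on a saturated ring carbon. For the measured compounds named here, the only measured step that bears on this exchange of phenyl for a five-membered heteroaryl is that same one, and it stayed within the scatter, so no move beyond the scatter is expected here either: the expected step is a number 5 percentage points higher from compound 2 to compound 3 (within the scatter). Compound 3 is therefore estimated at 18%, in the range 4% to 34%.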

Compound 3, a percentage reported as inhibition, at one concentration (the size of the read-out at that concentration, not a potency): 14%
The estimate for compound 3 lay 4 percentage points above the measured number; the measured number falls inside the stated range.
By their numbers in this assay, from the lowest: compounds 2, 3 and 1 (each within the scatter of the next).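

In this assay, furan-3-yl on the saturated ring carbon gives a reading indistinguishable from phenyl, with a number 1 percentage points higher from compound 2 to compound 3 (within the scatter), and from thiophen-3-yl, with a number 9 percentage points lower from compound 1 to compound 3 (within the scatter). This position has now taken three aromatic rings, five- and six-membered, with oxygen, sulfur or carbon only, and no exchange among them has moved the number beyond the scatter. No evidence is available to explain this.

On these data alone, it remains open whether an amine, a carboxylic acid or a longer alkyl chain on this carbon would move the number beyond the scatter. The same question stands for replacing the ethoxycarbonyl group on the shared core.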